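The source may report more compounds than this note shows. Statements on the series, on what has been measured and on what is new or still open speak of the compounds shown alone.

Measured compounds:
- Compound 1, `COc1ccc(NC(=O)c2cncc(N3CC4CC(C3)N4)c2)cc1OC`: 0.828 nM
- Compound 2, `O=C(Nc1ccc(F)cc1F)c1cncc(N2CC3CC(C2)N3)c1`: 0.051 nM

Compound 1 carries a 3,4-dimethoxyphenyl group on the amide nitrogen, and in an assay on membranes from Cerebral cortex for displacement of a labelled ligand from Neuronal acetylcholine receptor; alpha4/beta2 (Rattus norvegicus) (a lower number here means a stronger inhibitor, a higher number a weaker inhibitor), compound 1 gives 0.828 nM. Compound 2, with a 2,4-difluorophenyl group in the same position, gives 0.051 nM in this assay. Of the two numbers shown, compound 2 has the lower one, and the gap to compound 1 lies beyond the usual scatter, so compound 2 stands as the stronger inhibitor of the pair.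

Compound 3, `O=C(Nc1cccc(Cl)c1)c1cncc(N2CC3CC(C2)N3)c1`, has not been measured. It differs from compound 2 by 3-chlorophenyl in place of 2,4-difluorophenyl on an amide-type nitrogen. Among the compounds with values here, no measured pair shows this change, so its size cannot be read from the data. Both groups are halogenated phenyl rings of similar size on the same amide nitrogen. The step is expected to be small, estimated as a 2.0-fold higher number from compound 2 to compound 3 (0.29 log units; within the scatter). Compound 3 is therefore expected to give about 0.1 nM in this assay, in the range 0.03 nM to 0.4 nM.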

Compound 3, inhibition constant: 0.042 nM
The estimate for compound 3 lay 2.4-fold (0.38 log units) above the measured number; the range from low to high includes it.
By their numbers in this assay, from the lowest: compounds 3 and 2 (each within the scatter of the next); then compound 1.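

In this assay, replacing the group on the amide-type nitrogen gives a 1.2-fold lower number from compound 2 to compound 3 (0.08 log units; within the scatter), so the values of these two compounds cannot be told apart. Compound 1 and compound 2 had shown only that two substituted phenyl groups at this position can give clearly different numbers; this pair shows that 2,4-difluorophenyl and 3-chlorophenyl can give values within the scatter of each other, even though the kind of halogen, the number of halogens and their places on the ring all change in the same step. As these features change together, the step does not separate the contribution of any one of them, and no supporting measurement is available to explain the closeness of the two values.

The compounds shown leave open whether an unsubstituted phenyl ring, or a phenyl ring carrying a single fluorine, would give a value close to those of compound 2 and compound 3. They also leave open how a cyclohexyl group, or a phenyl ring bearing an amine or a carboxylic acid, would fare on the same amide nitrogen.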